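Series notes: a ring methyl added onto compound 2

The source may hold more compounds than are shown below. What is called first, only, known or untested is meant among the compounds shown, and "the series" means these compounds.

Measured compounds in a functional assay on Jurkat cells (Homo sapiens) for antiproliferative activity, read by MTT assay; a higher number here means a weaker inhibitor, a lower number a stronger inhibitor:
Compound 1 `COc1cc2c(cc1OC)C(=O)/C(=C/c1cccc([N+](=O)[O-])c1)CC2` gives 9000 nM.
Compound 2 `COc1cc2c(cc1OC)C(=O)/C(=C/c1cccc(C)c1)CC2` gives 17000 nM.
Compound 3 `COc1ccc(/C=C2\CCc3cc(OC)c(OC)cc3C2=O)c(OC)c1` reaches only the limit of the assay, > 50000 nM.

Compound 2 holds the higher of the two numbers given; its nearest neighbour is compound 1, and the step of a 1.9-fold higher number from compound 1 to compound 2 (0.28 log units; within the scatter) stays within the scatter. Compound 3 contributes no number, only (the limit of > 50000 nM in this assay, at which 1 of the 3 values shown sits).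

Compound 4 `COc1cc2c(cc1OC)C(=O)/C(=C/c1cc(C)ccc1C)CC2` differs from compound 2 by methyl in place of hydrogen on an aromatic carbon. Among the compounds with values here, the single measured step, a 1.9-fold higher number from compound 1 to compound 2 (0.28 log units; within the scatter), exchanges one group for another at a ring position and stays within the scatter; no measured step adds a group ortho to a large group. Compound 3, which carries an added methoxy group, sits at the limit > 50000 nM. For compound 4 a weaker inhibitor than compound 2 is therefore expected, the anticipated step being a 1.8-fold higher number from compound 2 to compound 4 (0.25 log units; within the scatter). The estimate for compound 4 in this assay is 30000 nM, with a range from 12000 nM to 80000 nM, and a real chance that only a limit is returned.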

Compound 4, half-maximal inhibitory concentration: 6000 nM
For compound 4 the middle estimate is 5.0-fold (0.70 log units) above the measured one, outside the stated range (below it).
By their numbers in this assay, from the lowest: compounds 4, 1 and 2 (each within the scatter of the next, the first and the last beyond it). At a limit, above all of these: compound 3.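

In this assay, within the data shown here, going from 3-methylphenyl to 2,5-dimethylphenyl gives a 2.8-fold lower number from compound 2 to compound 4 (0.45 log units; beyond the scatter), the only step beyond the scatter. The added methyl sits on an aromatic carbon, ortho to a large group and para to a methyl group, and here the addition lowers the number rather than raising it. The earlier step, a 1.9-fold higher number from compound 1 to compound 2 (0.28 log units; within the scatter), exchanged one group for another and stayed within the scatter, so it gave no reading on adding a group to this ring.

On these data alone, whether a methoxy group, a chlorine atom or an amine at the same position would also lower the number remains open. Compound 3 stays a limit and not a number, so it adds no readable step: the limit of > 50000 nM in this assay, at which 1 of the 4 values shown sits.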